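The compounds below may be only part of what the source reports. "The series", "measured", "known", "first", "only" and "open" are said of these compounds alone.

Working notes on the series. In an ADME assay on microsomes from liver (Mus musculus) for metabolic stability, using NADPH, with a stated time of 60 min (on this read-out higher numbers stand for fast clearance and lower numbers for slow clearance), compound 1 `CC(C)(C(=O)O)N1CCCN(c2ccc(F)c(C(F)(F)F)c2)C1=O` gives < 7 uL/min, which is a limit of the assay rather than a number. In this assay compound 2 `CC(C)(CC(=O)Nc1ccc(F)c(C(F)(F)F)c1)C(=O)O` likewise gives < 7 uL/min, again a limit, so compound 2 stands at the limit of < 7 uL/min in this assay, at which 2 of the 2 values shown sit, with no number of its own. Compound 3 `O=C(Nc1ccc(F)c(C(F)(F)F)c1)NC1(C(=O)O)CC1` is the next compound to be measured, differing from compound 2 by (1-carboxycyclopropyl)amino in place of 2-carboxy-2-methylpropyl on a carbonyl carbon. With both known values sitting at the same limit, no step beyond the usual scatter is expected from compound 2 to compound 3 in this assay. For compound 3 the estimate is 5 uL/min (range 2 uL/min to 12 uL/min), corresponding to an expected step that the limit leaves unreadable from compound 2 to compound 3.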

Compound 3, intrinsic clearance in a liver preparation (reported as CLH), per the amount of preparation that the assay uses: < 7 uL/min
Compound 3: only a limit was reported (the forecaster's own chance of this, stated with the estimate: 70%); the middle value is on the limit's open side.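

The step from compound 2 to compound 3 cannot be read in this assay, as both values are limits: the limit of < 7 uL/min in this assay, at which 3 of the 3 values shown sit.

On these data alone, whether compound 1, compound 2 and compound 3 differ at all in clearance stays open.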